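The source may report more compounds than this note shows. Statements on the series, on what has been measured and on what is new or still open speak of the compounds shown alone.

Of the compounds shown here, three of one family have been tested in a functional assay on RXF 393 cells (Homo sapiens) for cytotoxicity, read by sulforhodamine B assay, with a stated time of 48 h (on this read-out higher numbers stand for weaker inhibition of growth and lower numbers for stronger inhibition of growth), where compound 1 `ClCc1ccc(Cn2cnc3c(Cl)ncnc32)cc1` gives 2300 nM. Compound 2 `ClCc1ccccc1Cn1cnc2ncnc(Cl)c21` has the same atoms as compound 1, joined differently; the difference between the two cores is not broken down here. In this assay compound 2 gives 1650 nM, and its value and that of compound 1 lie within the scatter of each other, so nothing separates them. Compound 3 `ClCc1ccc(Cn2cnc3c(Cl)nc(Cl)nc32)cc1` gives 20900 nM. It differs from compound 1 by one change, (chloro in place of hydrogen on an aromatic carbon), and that change brought a 9.1-fold higher number from compound 1 to compound 3 (0.96 log units; beyond the scatter). Compound 3 is the weakest of the three, since its steps to both others are beyond the scatter.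

Compound 4 `ClCc1ccccc1Cn1cnc2nc(Cl)nc(Cl)c21` has not yet been measured in this assay. It differs from compound 2 by chloro in place of hydrogen on an aromatic carbon, and the surroundings of the new chloro group are described in the same words as for the change from compound 1 to compound 3, so this is the same change, made on the core of compound 2 rather than that of compound 1. For the measured compounds named here, the only guide is the one measured instance of it, so the expectation for compound 4 rests on compound 2 at 1650 nM together with the step seen from compound 1 to compound 3, and the step is expected to be a 7.9-fold higher number from compound 2 to compound 4 (0.90 log units; beyond the scatter). The change has been measured only once, and the room for error is wide. Compound 4 is therefore expected to give about 13000 nM, somewhere between 4000 nM and 40000 nM.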

Compound 4, concentration for 50% growth inhibition: 1 nM
Compound 4: the middle estimate sits 13000-fold (4.11 log units) above what was measured, outside the stated range (below it).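

In this assay, placing a chloro group on the aromatic carbon between two ring nitrogen atoms gave a 1700-fold lower number from compound 2 to compound 4 (3.22 log units; beyond the scatter), so on this core the change goes with much stronger inhibition of growth, whereas on the core of compound 1 it went with weaker inhibition. The result from one core therefore cannot be carried over to the other in this series, as the two measured instances differ in direction as well as in size: the same change on two cores in this assay, a 9.1-fold higher number (0.96 log units; beyond the scatter) from compound 1 to compound 3 and a 1700-fold lower number (3.22 log units; beyond the scatter) from compound 2 to compound 4, 15000-fold (4.18 log units) apart, beyond the scatter of two such steps

With only these two instances, the data do not show why the two cores part ways, or which of them a third core would follow.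

The compounds shown leave open whether the large step on the core of compound 2 belongs to chloro itself, or whether another group on that same carbon, such as an amine or a methoxy group, would give a similar result. They also leave open whether the result depends on the chloromethyl group carried by all four compounds, which a compound with a plain methyl group in its place could test.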